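Aniline variation on the shared core in the cell assay

A few compounds are considered here, and "the series" means these few. Any claim that something is new, unique, unknown or untested is made for them only; others in the source may bear on it.

Compound 1 `Cc1n[nH]c2ccc(-c3nc4cnc(N5CCN(C)CC5)cn4c3Nc3cccc(F)c3)cc12` carries a 3-fluorophenyl on a nitrogen on an aromatic ring of the shared core. Going by the values given here, in a functional assay on MV4-11 cells (Homo sapiens) for inhibition, with a stated time of 120 h, tested at 10 uM (a higher number here means more inhibition at the concentration tested (going by the name of the read-out), a lower number less inhibition), compound 1 gives 18.5%, the higher of the two numbers so far. Compound 2 `Cc1ccc(C)c(Nc2c(-c3ccc4[nH]nc(C)c4c3)nc3cnc(N4CCN(C)CC4)cn23)c1`, which carries a 2,5-dimethylphenyl in the same place, gives 0% in this assay, and the step of a number 18.5 percentage points lower from compound 1 to compound 2 (beyond the scatter) shows that exchanging the aryl group on that nitrogen has so far cost activity.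

Compound 3 `COc1ccc(Nc2c(-c3ccc4[nH]nc(C)c4c3)nc3cnc(N4CCN(C)CC4)cn23)cc1OC` is not yet measured. Relative to compound 1 the change is 3,4-dimethoxyphenyl in place of 3-fluorophenyl on a nitrogen on an aromatic ring. Among the compounds with values here, the only measured step that bears on it is the aryl exchange from compound 1 to compound 2, which removed all measurable inhibition; no step with an oxygen-bearing aryl group is available, so the direction for the 3,4-dimethoxyphenyl cannot be read directly. Starting from a low number, a modest drop or no change beyond the scatter is the expected outcome, giving an estimated step of a number 8.5 percentage points lower from compound 1 to compound 3 (within the scatter). Compound 3 is expected to give about 10% in this assay, within the range 0% to 30%.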

Compound 3, a percentage reported as inhibition, at one concentration (the size of the read-out at that concentration, not a potency): 6.27%
Estimate against measurement, compound 3: 3.7 percentage points above; measured number inside the range.
By their numbers in this assay, from the lowest: compounds 2 and 3 (each within the scatter of the next); then compound 1.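

In this assay, the loss of inhibition on leaving 3-fluorophenyl is no longer tied to 2,5-dimethylphenyl alone: a number 12.2 percentage points lower from compound 1 to compound 3 (beyond the scatter), so two differently substituted phenyl groups on that nitrogen now fall short of compound 1. The two replacements cannot be separated, since a number 6.3 percentage points higher from compound 2 to compound 3 (within the scatter), and the dimethoxy and dimethyl substitutions therefore give no ordering in this read-out. Among these three compounds, 3-fluorophenyl gives the highest number, although compound 1 reaches only 18.5%, and nothing available accounts for the differences at this position.

An unsubstituted phenyl or a 3-chlorophenyl on that nitrogen would show whether the fluorine itself goes with the higher number or whether any small single substituent serves equally well. Also open, on these data alone, is whether a group other than a substituted phenyl, such as a pyridyl or a cyclohexyl, can occupy this place and raise inhibition beyond the modest level of compound 1 in this assay.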